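Closing an Open Chain into a Cyclopentyl Ring

The compounds below may be only part of what the source reports. "The series", "measured", "known", "first", "only" and "open" are said of these compounds alone.

Three measured compounds share a core and differ only in the saturated group attached to the sulfonyl sulfur. Compound 1 `O=S(=O)(/C=C/c1ccc(O)c(O)c1)CC1CCCN1` carries a pyrrolidin-2-yl group; in a functional assay, read by fluorescence and spectrophotometry, with a stated time of 1 h (a lower number here means that less compound is needed, a higher number that more compound is needed for the effect), compound 1 gives 13800 nM. Compound 2 `CCCCCCS(=O)(=O)/C=C/c1ccc(O)c(O)c1` has pentyl in place of pyrrolidin-2-yl on a saturated chain carbon bound to a sulfonyl sulfur, and in this assay compound 2 gives 7300 nM. Compound 3 `C=CCCCCCCS(=O)(=O)/C=C/c1ccc(O)c(O)c1` has hept-6-en-1-yl in that place, and in this assay compound 3 gives 6400 nM, the lowest of the three numbers; against compound 2 the gap is a 1.1-fold lower number from compound 2 to compound 3 (0.06 log units; within the scatter), and against compound 1 it is a 2.2-fold lower number from compound 1 to compound 3 (0.33 log units; beyond the scatter).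

Compound 4 `O=S(=O)(/C=C/c1ccc(O)c(O)c1)CCC1CCCC1` has not yet been measured. It differs from compound 3 in one place: cyclopentyl in place of hex-5-en-1-yl on a saturated chain carbon, two bonds along the chain from a sulfonyl sulfur. Among the compounds with values here, the steps that bear on this all alter the same saturated group: a 1.9-fold lower number from compound 1 to compound 2 (0.28 log units; within the scatter), a 2.2-fold lower number from compound 1 to compound 3 (0.33 log units; beyond the scatter) and a 1.1-fold lower number from compound 2 to compound 3 (0.06 log units; within the scatter). Each of these changes, including one that swapped a ring for an open chain, moved the number by little, so in this assay no step beyond the scatter is expected, in either direction. Compound 4 is therefore estimated at 6500 nM, with a range from 3000 nM to 14000 nM. This estimate means a step of a 1.0-fold higher number from compound 3 to compound 4 (0.01 log units; within the scatter).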

Compound 4, half-maximal effective concentration: 6800 nM
For compound 4 the middle estimate is 1.0-fold (0.02 log units) below the measured one, and the stated range covers the measured number.
By their numbers in this assay, from the lowest: compounds 3, 4, 2 and 1 (each within the scatter of the next, the first and the last beyond it).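

In this assay, tying the open chain into a ring at this place, two bonds along the chain from the sulfonyl sulfur, leaves the number within the scatter: cyclopentyl in place of hex-5-en-1-yl gives a 1.1-fold higher number from compound 3 to compound 4 (0.03 log units; within the scatter), and cyclopentyl in place of butyl gives a 1.1-fold lower number from compound 2 to compound 4 (0.03 log units; within the scatter). The chain's double bond and its freely extended shape are therefore not needed to keep the number where the open-chain compounds put it, since an all-carbon ring reads the same within the scatter. Within the data shown here, the earlier compounds held only one ring, the nitrogen-containing pyrrolidin-2-yl, so a ring and a higher number could not be told apart; cyclopentylmethyl in place of pyrrolidin-2-yl now gives a 2.0-fold lower number from compound 1 to compound 4 (0.31 log units; beyond the scatter), which shows that a ring at this place does not by itself go with the highest number.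

Nothing shown here offers an explanation for these numbers. On these data alone, it remains open how this place would respond to an amine or a carboxylic acid at the end of the chain, to a larger ring such as cyclohexyl, or to a much shorter chain such as ethyl.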